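This account rests on a few compounds, and the source may have more. Where it says the series, first, only, none or still open, it means among the compounds named here.

Measured so far, in a functional assay on HCT-116 cells (Homo sapiens) for inhibition, read by MTT assay, with a stated time of 72 h; a lower number here means a stronger inhibitor of growth, a higher number a weaker inhibitor of growth:
- compound 1, `CNC(=O)/C=C/c1ccncc1-c1ccc2ccccc2c1`: 6550 nM
- compound 2, `NNC(=O)COc1ccncc1-c1ccc2ccccc2c1`: "not determined" (no result reported)
- compound 3, `O=C(O)COc1ccncc1-c1ccc2ccccc2c1`: "not determined" (no result reported)

Compound 1 is the only one of the three with a number in this assay, so there is no measured comparison to lean on. Compound 4, `COC1CN(C(=O)/C=C/c2ccncc2-c2ccc3ccccc3c2)C1`, is the next compound in line. It differs from compound 1 in one place: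

3-methoxyazetidin-1-yl in place of methylamino on a carbonyl carbon

A methylamino group with one hydrogen-bond donor gives way to a ring-bearing group with an acceptor instead. Among the measured compounds shown here, with no measured pair to set a scale, the expected step is small, possibly none beyond the usual scatter, and its direction is uncertain. The estimated step is a 1.3-fold lower number from compound 1 to compound 4 (0.12 log units; within the scatter). Compound 4 is therefore expected to give about 5000 nM, with a likely range from 1500 nM to 16000 nM.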

Compound 4, concentration for 50% growth inhibition: > 30000 nM
Compound 4 was reported as a limit (the forecaster's own chance of this, stated with the estimate: 10%); middle value at least 6.0-fold (0.77 log units) from the limit.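

In this assay, the group on this carbonyl carbon clearly matters: 3-methoxyazetidin-1-yl in place of methylamino gives an at least 4.5-fold higher number from compound 1 to compound 4 (0.66 log units; beyond the scatter). So this change weakens growth inhibition rather than leaving it unchanged, which compound 1 alone could not show. The step rests on a limit, not a number, for compound 4: the limit of > 30000 nM in this assay, at which 1 of the 4 values shown sits.

The compounds shown leave open whether the weakening comes with the loss of the amide hydrogen or with the added ring and methoxy group, as this one change alters all of them. Dimethylamino or unsubstituted azetidin-1-yl on the same carbonyl carbon would help separate these.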